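Series notes: from compound 1 to compound 4

The compounds below may be only part of what the source reports. "The series", "measured", "known", "first", "only" and "open" are said of these compounds alone.

Measured so far in an ADME assay on cells (Mus musculus, strain BALB/C) for cytotoxicity, read by MTT assay, with a stated time of 24 h; a lower number here means that less compound is tolerated, a higher number that more compound is tolerated:
compound 1 `COc1ccc(/C=N/NC(=O)c2ccc(C)cc2O)cc1` gives 723000 nM
compound 2 `Cc1ccc(C(=O)N/N=C/c2ccccc2O)c(O)c1` gives 761000 nM
compound 3 `Cc1ccc(C(=O)N/N=C/c2cc(Cl)ccc2O)c(O)c1` gives 560000 nM

Compound 1 stands second highest of the three numbers in this assay. Its nearest neighbour is compound 2, whose value sits within the scatter of it, and the furthest is compound 3, whose value is also within the scatter of it; the three numbers therefore cannot be ordered against one another.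

Compound 4 `Cc1ccc(C(=O)N/N=C/c2ccc(N(C)C)cc2)c(O)c1` differs from compound 1 in one place: dimethylamino in place of methoxy on an aromatic carbon.

Within the data shown here, the only measured step is a 1.4-fold lower number from compound 2 to compound 3 (0.13 log units; within the scatter), a change on the other aromatic ring of the shared core, and it stays within the scatter. Among the measured compounds shown here, no measured step touches the position that changes from compound 1 to compound 4, and no measured compound carries a dimethylamino group, so nothing in the data points to a direction. Given that the one measured step is within the scatter and the three values lie close together, the expectation is that the change from compound 1 to compound 4 gives no step beyond the scatter, a 1.0-fold lower number from compound 1 to compound 4 (0.01 log units; within the scatter).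

Compound 4 is therefore estimated at 700000 nM in this assay, with a range from 400000 nM to 1200000 nM.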

Compound 4, half-maximal cytotoxic concentration: 732000 nM
Estimate against measurement, compound 4: 1.0-fold (0.02 log units) below, within the range that was stated.
By their numbers in this assay, from the lowest: compounds 3, 1, 4 and 2 (each within the scatter of the next).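

In this assay, among these compounds, dimethylamino in place of methoxy on an aromatic carbon, para to a large group, gives a 1.0-fold higher number from compound 1 to compound 4 (0.01 log units; within the scatter), the first measured step at this position. The change from a group of 2 heavy atoms to one of 3, with the same hydrogen-bond donor and acceptor counts and no net charge on either side, therefore stays within the scatter in this assay, and the two groups cannot be told apart here. Nothing measured in the series bears on why this exchange leaves the number within the scatter.

The compounds shown leave open whether a carboxylic acid, a primary amine or a longer alkoxy chain at this position would also stay within the scatter, since methoxy and dimethylamino are the only two groups compared here in a single-place change. As far as these compounds go, both steps read so far lie within the scatter, so it also remains open whether any single change on the shared core can move the number beyond it.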